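This account rests on a few compounds, and the source may have more. Where it says the series, first, only, none or still open, it means among the compounds named here.

Measured compounds in a functional assay on MCF7 cells (Homo sapiens) for cytotoxicity, read by MTT assay, with a stated time of 72 h (on this read-out lower numbers stand for stronger inhibition and higher numbers for weaker inhibition), so far
- compound 1 `COc1ccc(OC)c(/C=C/C(=O)Nc2cc3c(Nc4ccc(F)c(Cl)c4)ncnc3cc2OC)c1` gives 34300 nM in this series
- compound 2 `COc1ccc(/C=C/C(=O)Nc2cc3c(Nc4ccc(F)c(Cl)c4)ncnc3cc2OC)c(OC)c1` gives 36600 nM in this series

Compound 2 stands level with compound 1 within the scatter, and no other measured number is available to place it against. Next comes compound 3 `COc1cc2ncnc(Nc3ccc(F)c(Cl)c3)c2cc1NC(=O)/C=C/c1ccc(C#N)cc1`, with the change 4-cyanophenyl in place of 2,4-dimethoxyphenyl on a double-bonded chain carbon bound to a double-bonded chain carbon in the series: 4-cyanophenyl in place of 2,4-dimethoxyphenyl on a double-bonded chain carbon bound to a double-bonded chain carbon. Within the data shown here, the only measured step, a 1.1-fold higher number from compound 1 to compound 2 (0.03 log units; within the scatter), lies within the scatter and exchanges 2,5-dimethoxyphenyl for 2,4-dimethoxyphenyl. Among the measured compounds shown here, no measured step removes the dimethoxyphenyl group or brings in a nitrile, so the guidance is weak and no direction is supported. In this assay no step beyond the scatter is expected. The estimated step is a 1.5-fold lower number from compound 2 to compound 3 (0.17 log units; within the scatter) and carries wide uncertainty. For compound 3 the estimated value is 25000 nM with an expected range from 7000 nM to 70000 nM in this assay.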

Compound 3, half-maximal inhibitory concentration: "not active" (no number reported)
No number was reported for compound 3; the estimate stays without a comparison.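

In this assay, among these compounds, compound 3 is recorded as not active without a number, and no step from compound 2 to compound 3 can be read. No evidence bears on this result. The compounds shown leave open how 4-cyanophenyl in place of 2,4-dimethoxyphenyl changes the read-out.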